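Removing the (Benzyloxycarbonyl)amino Group: Expected Stability

The source may hold more compounds than are shown below. What is called first, only, known or untested is meant among the compounds shown, and "the series" means these compounds.

Compound 1 `COc1cc(-c2c(C)nc3c(N4CC[C@@H](NC(C)=O)C4)cc(C)nn23)ccc1F` and compound 2 `COc1ccc(-c2c(C)nc3c(N4CC[C@@H](NC(=O)OCc5ccccc5)C4)cc(C)nn23)cc1OC` share a core and were both tested in an ADME assay on microsomes from liver (Mus musculus) for metabolic stability, read by LC-MS, with NADPH named in the record, with a stated time of 60 min, tested at 1 uM, in the absence of a further agent; on this read-out higher numbers stand for a more stable compound and lower numbers for a less stable compound. Compound 1 gives > 95%, which is a limit of the assay rather than a number. Compound 2 gives > 95%, again a limit and not a number. Both thus sit at the limit of > 95% in this assay, at which 2 of the 2 values shown sit, so compound 2 stands at the top of what this assay reports. Compound 3 `COc1ccc(-c2c(C)nc3c(N4CCCC4)cc(C)nn23)cc1OC` differs from compound 2 by hydrogen in place of (benzyloxycarbonyl)amino on a saturated ring carbon. Within the data shown here, no measured pair shows what such a change does here, so the step from compound 2 to compound 3 can only be estimated: a modest fall, close to the scatter, is expected from a number at least 10 percentage points lower from compound 2 to compound 3 (that floor lies within the scatter). Compound 3 is therefore expected at 85%, between 60% and 98%.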

Compound 3, percent of the compound remaining: > 95%
Compound 3: no number, only a limit; the forecaster's own chance of this, stated with the estimate: 40%; middle value at least 10 percentage points from the limit.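

No step can be read from compound 2 to compound 3, because each gives only a limit rather than a number: the limit of > 95% in this assay, at which 3 of the 3 values shown sit.

What hydrogen in place of (benzyloxycarbonyl)amino does to stability remains open, as does any ranking among these compounds.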